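The source may hold more compounds than are shown below. What is called first, only, known or untested is meant among the compounds shown, and "the series" means these compounds.

Measured in a functional assay on A549 cells (Homo sapiens) for inhibition, read by MTT assay, with a stated time of 72 h; a higher number here means a weaker inhibitor, a lower number a stronger inhibitor:
compound 1 `Nc1ncnc2c1c(-c1cnc3[nH]ccc3c1)nn2CCCCCCC(=O)NO`: 50000 nM
compound 2 `Nc1nc2cc(-c3nn(CCCCC(=O)NO)c4ncnc(N)c34)ccc2o1`: > 100000 nM (a limit of the assay, not a number)
compound 3 `Nc1nc2cc(-c3nn(CCCCCCCCC(=O)NO)c4ncnc(N)c34)ccc2o1`: 13200 nM

Compound 3, at 13200 nM, holds the lower of the two true numbers. Compound 1 gives 50000 nM, and the gap between these two numbers lies beyond the scatter. Compound 4 `Nc1nc2cc(-c3nn(CCCCCCC(=O)NO)c4ncnc(N)c34)ccc2o1` differs from compound 3 as follows: hydroxycarbamoyl in place of 2-(hydroxycarbamoyl)ethyl on a saturated chain carbon, six bonds along the chain from an aromatic nitrogen. Going by the values given here, only one measured step bears on this change, the chain extension an at least 7.5-fold lower number from compound 2 to compound 3 (0.87 log units; beyond the scatter), which lay beyond the scatter. Compound 4 undoes part of that extension, so a move towards a higher number, beyond the scatter but smaller than that step, is expected in this assay. The expected step is a 3.0-fold higher number from compound 3 to compound 4 (0.48 log units; beyond the scatter). For compound 4 the estimated value is 40000 nM, with an expected range of 18000 nM to 100000 nM.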

Compound 4, half-maximal inhibitory concentration: 33000 nM
Estimate against measurement, compound 4: 1.2-fold (0.08 log units) above, within the range that was stated.
By their numbers in this assay, from the lowest: compound 3; then compounds 4 and 1 (each within the scatter of the next). At a limit, above all of these: compound 2.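

In this assay, shortening the chain on the shared core gives a graded change (a 2.5-fold higher number from compound 3 to compound 4 (0.40 log units; beyond the scatter)), so the chain of compound 4 keeps part of the gain seen with the longest chain. The step from the shortest chain (an at least 3.0-fold lower number from compound 2 to compound 4 (0.48 log units; beyond the scatter)) starts from a limit of the assay, not a number: the limit of > 100000 nM in this assay, at which 1 of the 4 values shown sits. At this chain length, exchanging the aromatic group on the core gives no change beyond the scatter (a 1.5-fold lower number from compound 1 to compound 4 (0.18 log units; within the scatter)). On these data alone, whether a chain longer than that of compound 3 lowers the number further remains open, as does the effect of a carboxylic acid or an amine in place of hydroxycarbamoyl.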